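This account rests on a few compounds, and the source may have more. Where it says the series, first, only, none or still open, it means among the compounds named here.

Compound 2 `COc1ccc(COC[C@H]2C/C(C)=C/COCC/C=C/C(=O)C/C(C)=C\C=C\C(=O)N2)cc1` gives 4400 nM in a functional assay on PC-3 cells (Homo sapiens) for antiproliferative activity, read by WST assay, with a stated time of 3 days (on this read-out higher numbers stand for weaker inhibition and lower numbers for stronger inhibition), the lower of the two numbers recorded so far; compound 1 `C/C1=C/C=C/C(=O)N[C@@H](C=O)C/C(C)=C/COCC/C=C/C(=O)C1` gives 10200 nM. Compound 3 `C/C1=C/C=C/C(=O)N[C@@H](CO)C/C(C)=C/COCC/C=C/C(=O)C1` carries hydrogen in place of 4-methoxybenzyl on an oxygen on a saturated carbon. Among the compounds with values here, no measured step matches this change directly; the only step available, a 2.3-fold lower number from compound 1 to compound 2 (0.37 log units; beyond the scatter), concerns the group on a saturated ring carbon and bears on it only loosely. Loss of the 4-methoxybenzyl is expected to move the number modestly back toward compound 1, beyond the scatter but not far. Compound 3 is expected to read 8000 nM (3000 nM to 25000 nM), a step of a 1.8-fold higher number from compound 2 to compound 3 (0.26 log units; within the scatter).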

Compound 3, half-maximal inhibitory concentration: > 12500 nM
Compound 3: a limit, no number; the forecaster's own chance of this, stated with the estimate: 10%; middle value at least 1.5-fold (0.19 log units) away from the limit.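

In this assay compound 3 reads as a limit and not a number: the limit of > 12500 nM in this assay, at which 1 of the 3 values shown sits.
Taking the 4-methoxybenzyl off this oxygen gives an at least 2.8-fold higher number from compound 2 to compound 3 (0.45 log units; beyond the scatter), so at this position the lower number goes with the intact ((4-methoxybenzyl)oxy)methyl group, not with the free hydroxymethyl. Hydroxymethyl in place of formyl gives an at least 1.2-fold higher number from compound 1 to compound 3 (0.08 log units; that floor lies within the scatter), so those two groups cannot be ordered.

Open, on these data alone, is whether the aromatic ring or the ether oxygen carries the gain, and whether a plain benzyl ether, an amine or a carboxylic acid at this carbon would match compound 2.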